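Series notes: from compound 3 to compound 4

The source may hold more compounds than are shown below. What is called first, only, known or untested is meant among the compounds shown, and "the series" means these compounds.

Measured so far in a functional assay on T47D cells (Homo sapiens) for cytotoxicity, read by MTT assay, with a stated time of 24 h; a higher number here means a weaker inhibitor, a lower number a stronger inhibitor:
compound 1 `COc1ccc(/C=C\C(=O)O)c(OCc2cn(-c3ccccc3F)nn2)c1CC=C(C)C`: 11000 nM
compound 2 `COc1ccc(-n2cc(COc3c(/C=C\C(=O)O)ccc(OC)c3CC=C(C)C)nn2)cc1`: "not determined" (no result reported)
compound 3 `COc1ccc(/C=C\C(=O)O)c(OCc2cn(-c3ccccc3I)nn2)c1CC=C(C)C`: "not determined" (no result reported)

Compound 3 stands without a number in this assay, as does compound 2; only compound 1 carries a value on the shared core. Compound 4 `COc1ccc(/C=C\C(=O)O)c(OCc2cn(-c3ccccc3C#N)nn2)c1CC=C(C)C` is the next entry. The change from compound 3 to compound 4 is cyano in place of iodo on an aromatic carbon. Within the data shown here, no step between measured compounds is known, so no size can be read from the series itself; the working expectation is a step no larger than the usual scatter, with its direction undecided. Resting on compound 1 alone, which gives 11000 nM in this assay, compound 4 is expected near 11000 nM, within 3000 nM to 40000 nM.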

Compound 4, half-maximal inhibitory concentration: 8800 nM
Compound 4: middle estimate off by 1.3-fold (0.10 log units), on the high side; the measured number falls inside the stated range.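

In this assay the series gives a 1.3-fold lower number from compound 1 to compound 4 (0.10 log units; within the scatter) and this step lies within the scatter. Cyano and fluoro on this aromatic carbon, ortho to a large group, therefore cannot be told apart, so this swap brings no readable shift. Steps involving compound 2 or compound 3 cannot be read, neither compound having a number, and iodo stays unplaced.

From the compounds shown here alone, whether an amine or a carboxylic acid on this aromatic carbon would shift the number remains open. No measurement shown explains why cyano and fluoro read alike.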